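Swapping Propyl for Chloro in a Stomach Assay

This account rests on a few compounds, and the source may have more. Where it says the series, first, only, none or still open, it means among the compounds named here.

Measured in a functional assay on the whole organism (stomach) with Rattus norvegicus as the target; on this read-out lower numbers stand for an effect already at smaller amounts and higher numbers for an effect only at larger amounts of compound:
- compound 1 `CCCc1ccc(C(=O)Nc2cc(C(=O)O)cc(C(=O)O)c2)cc1`: 94.2 mg/kg
- compound 2 `O=C(O)c1cc(NC(=O)c2cc(O)cc(O)c2)cc(C(=O)O)c1`: 90.2 mg/kg
- compound 3 `N#Cc1ccc(C(=O)Nc2ccc(-c3nn[nH]n3)cc2)cc1`: 54.4 mg/kg

All three values lie within the scatter of one another, so compound 1 stands level with compound 2 and compound 3 on these numbers. Compound 4 `O=C(O)c1cc(NC(=O)c2ccc(Cl)cc2)cc(C(=O)O)c1` has chloro in place of propyl on an aromatic carbon of the core of compound 1 (chloro in place of propyl on an aromatic carbon). Going by the values given here, no measured pair isolates this change, so no size of step can be read from the data. The expected step of a 1.2-fold lower number from compound 1 to compound 4 (0.07 log units; within the scatter) stays within the scatter. For compound 4 the estimated value is 80 mg/kg, with an expected range of 40 mg/kg to 160 mg/kg.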

Compound 4, dose for 50% inhibition: 97.3 mg/kg
Compound 4: middle estimate off by 1.2-fold (0.09 log units), on the low side; measured number inside the range.
By their numbers in this assay, from the lowest: compounds 3, 2, 1 and 4 (each within the scatter of the next).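

At the position para to a large group on the core of compound 1, this assay gives the first step measured for a single change: chloro in place of propyl brings a 1.0-fold higher number from compound 1 to compound 4 (0.01 log units; within the scatter) and leaves the two compounds level. On these numbers, a single chlorine atom and a chain of three carbons at this position cannot be told apart. Nothing available accounts for this result. As far as these compounds go, whether an amine or a longer chain such as hexyl at this position would give a step beyond the scatter remains open. So does whether the same swap would give a comparable step on another core.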